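The compounds below may be only part of what the source reports. "The series", "measured", "known", "first", "only" and "open" are said of these compounds alone.

In a functional assay on U2OS cells (Homo sapiens) for cytotoxicity, read by MTT assay, with a stated time of 48 h (on this read-out higher numbers stand for weaker inhibition and lower numbers for stronger inhibition), compound 3 `Fc1cccc(-c2nc(Nc3ccc(Cl)cc3)c3cc(F)ccc3n2)c1` gives 38400 nM, one of only two numbers shown. Compound 2 `Fc1cccc(Nc2nc(-c3cccc(F)c3)nc3ccc(F)cc23)c1` gives 49600 nM, and the step of a 1.3-fold lower number from compound 2 to compound 3 (0.11 log units; within the scatter) lies within the scatter. Compound 1 `Fc1ccc(Nc2nc(-c3cccc(F)c3)nc3ccc(F)cc23)cc1` gives > 50000 nM, which is a limit of the assay and not a number (the limit of > 50000 nM in this assay, at which 1 of the 3 values shown sits). Compound 4 `Fc1cccc(-c2nc(Nc3cccc(Cl)c3)c3cc(F)ccc3n2)c1` differs from compound 3 by 3-chlorophenyl in place of 4-chlorophenyl on a nitrogen on an aromatic ring. For the measured compounds named here, the one measured step of the same kind, a number no higher from compound 1 to compound 2 (the limit leaves the size open), starts from a limit, so its size cannot be read, and an at least 1.3-fold lower number from compound 1 to compound 3 (0.11 log units; that floor lies within the scatter) is only a floor within the scatter. Nothing here points to a shift beyond the scatter, so compound 4 is expected to show a step of a 1.0-fold higher number from compound 3 to compound 4 (0.02 log units; within the scatter). Compound 4 is estimated at 40000 nM, between 20000 nM and 80000 nM.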

Compound 4, half-maximal inhibitory concentration: > 50000 nM
Compound 4: a limit, no number; the forecaster's own chance of this, stated with the estimate: 30%; at least 1.2-fold (0.09 log units) between middle value and limit.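

From the compounds shown here alone, the change to 3-chlorophenyl in place of 4-chlorophenyl gives an at least 1.3-fold higher number from compound 3 to compound 4 (0.11 log units; that floor lies within the scatter), so this move of the chlorine shows no shift beyond the scatter, although its true size stays open. Compound 4 sits at a limit of the assay, not at a number, as compound 1 does: the limit of > 50000 nM in this assay, at which 2 of the 4 values shown sit. Chloro in place of fluoro gives a number no lower from compound 2 to compound 4 (the limit leaves the size open), and neither this step nor the remaining step to compound 4 can be read, so chloro in place of fluoro cannot be compared on the two cores: the same change on two cores in this assay, an at least 1.3-fold lower number (0.11 log units; that floor lies within the scatter) from compound 1 to compound 3 and a number no lower (the limit leaves the size open) from compound 2 to compound 4; the limit leaves it open whether they differ.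

Still open, going by these compounds, is whether a phenyl ring on this nitrogen carrying an amine or a carboxylic acid would give a clearly lower number.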